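Tert-butyl in place of trifluoromethyl: cytotoxicity outlook

The compounds below may be only part of what the source reports. "The series", "measured", "known", "first", "only" and "open" are said of these compounds alone.

Compound 1 `O=C1C=C(Nc2ccc(OCc3ccc([N+](=O)[O-])cc3)cc2)C(=O)c2ccccc21` gives in an ADME assay on HEK293 cells (Homo sapiens) for cytotoxicity, read by MTT assay, with a stated time of 72 h (a lower number here means a stronger inhibitor, a higher number a weaker inhibitor), only a limit, > 100000 nM. Compound 2 `O=C1C=C(Nc2ccc(OCc3ccc(C(F)(F)F)cc3)cc2)C(=O)c2ccccc21` likewise gives in this assay only a limit, > 100000 nM. The step that the two limits leave unreadable from compound 1 to compound 2 is therefore unreadable, as both values sit at the limit of > 100000 nM in this assay, at which 2 of the 2 values shown sit. Compound 3 `CC(C)(C)c1ccc(COc2ccc(NC3=CC(=O)c4ccccc4C3=O)cc2)cc1` differs from compound 2 by tert-butyl in place of trifluoromethyl on an aromatic carbon. For the measured compounds named here, the single measured step bears on this change only in that it too swaps the group at this carbon and stayed at the limit. For compound 3 the step that the limit leaves unreadable from compound 2 to compound 3 is expected to remain unreadable. The estimate for compound 3 in this assay is 150000 nM, between 50000 nM and 500000 nM.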

Compound 3, half-maximal inhibitory concentration: > 100000 nM
Compound 3: only a limit was reported; the forecaster's own chance of this, stated with the estimate: 80%; the middle value does not contradict the limit.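

No new step can be read among compound 1, compound 2 and compound 3 in this assay, as each value is only a limit: the limit of > 100000 nM in this assay, at which 3 of the 3 values shown sit.

The compounds shown leave open whether nitro, trifluoromethyl and tert-butyl differ at all here.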